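A bromophenyl swap on a compound stuck at the limit

The source may hold more compounds than are shown below. What is called first, only, known or untested is meant among the compounds shown, and "the series" means these compounds.

- compound 1 `COc1cccc(/C=C2\CCC/C(=C\c3ccccc3Br)C2=O)c1OC`: > 20000 nM (a limit)
- compound 2 `COc1cccc(/C=C2\CCC/C(=C\c3cccc(Br)c3)C2=O)c1OC`: > 20000 nM (a limit)

In a functional assay on A549 cells (Homo sapiens) for cytotoxicity, read by MTT assay, with a stated time of 72 h (a lower number here means a stronger inhibitor, a higher number a weaker inhibitor), compound 2 gives > 20000 nM, which is a limit and not a number. Compound 1 likewise gives only a limit, > 20000 nM. The evidence so far is thin: the limit of > 20000 nM in this assay, at which 2 of the 2 values shown sit. Compound 3 `COc1cccc(/C=C2\CCC/C(=C\c3ccc(Br)cc3)C2=O)c1OC` differs from compound 2 in one place: 4-bromophenyl in place of 3-bromophenyl on a double-bonded chain carbon bound to a double-bonded ring carbon. Among the compounds with values here, the one measured step, a step that the two limits leave unreadable from compound 1 to compound 2, is also a bromophenyl swap, but its size cannot be read. No change beyond the usual scatter is therefore expected in this assay, and the estimated step is a step that the limit leaves unreadable from compound 2 to compound 3. Compound 3 is expected at about 22000 nM, with an estimated range of 9000 nM to 40000 nM.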

Compound 3, half-maximal inhibitory concentration: > 20000 nM
Compound 3: a limit, no number (the forecaster's own chance of this, stated with the estimate: 70%); the middle value is on the limit's open side.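

Compound 3 gives > 20000 nM, again a limit and not a number. Within the data shown here, no step among compound 1, compound 2 and compound 3 can therefore be read. Going by these compounds, whether 2-bromophenyl, 3-bromophenyl and 4-bromophenyl differ at all in this assay stays open.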